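Benzoyl to (trifluoromethyl)carbonyl on the shared core

The source may hold more compounds than are shown below. What is called first, only, known or untested is meant among the compounds shown, and "the series" means these compounds.

Measured in a functional assay on A549 cells (Homo sapiens) for antiproliferative activity, read by MTT assay; on this read-out higher numbers stand for weaker inhibition and lower numbers for stronger inhibition:
- compound 1 `CCOC(=O)N1CCCc2cc(S(=O)(=O)N3CC(c4ccccc4)NC3=O)ccc21`: 344 nM
- compound 2 `CCCCOC(=O)N1CCCc2cc(S(=O)(=O)N3CC(c4ccccc4)NC3=O)ccc21`: > 20000 nM
- compound 3 `O=C(c1ccccc1)N1CCCc2cc(S(=O)(=O)N3CC(c4ccccc4)NC3=O)ccc21`: 8140 nM

Compound 2 gives > 20000 nM, which is a limit of this assay. Of the two actual numbers, the higher belongs to compound 3 at 8140 nM. Compound 4 `O=C1NC(c2ccccc2)CN1S(=O)(=O)c1ccc2c(c1)CCCN2C(=O)C(F)(F)F` differs from compound 3 by trifluoromethyl in place of phenyl on a carbonyl carbon. Two measured steps alter this same carbonyl substituent, though neither involves trifluoromethyl. The large step of a 24-fold higher number from compound 1 to compound 3 (1.37 log units; beyond the scatter) adds phenyl in place of ethoxy, whereas an at least 2.4-fold lower number from compound 2 to compound 3 (0.39 log units; beyond the scatter) is at least modest and runs the opposite way. Weighing the large step from ethoxy more heavily, a moderate fall in this assay is expected, with wide uncertainty. The expected change is a 3.3-fold lower number from compound 3 to compound 4 (0.51 log units; beyond the scatter). Compound 4 is estimated at 2500 nM, with an expected range of 300 nM to 15000 nM.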

Compound 4, half-maximal inhibitory concentration: > 20000 nM
Compound 4: no number, only a limit; the forecaster's own chance of this, stated with the estimate: 15%; middle value at least 8.0-fold (0.90 log units) away from the limit.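

The reading for compound 4 is a limit of this assay, not a number: the limit of > 20000 nM in this assay, at which 2 of the 4 values shown sit. Trifluoromethyl on this carbonyl carbon still gives an at least 2.4-fold higher number from compound 3 to compound 4 (0.39 log units; beyond the scatter) and an at least 58-fold higher number from compound 1 to compound 4 (1.76 log units; beyond the scatter), so replacing phenyl with this non-aromatic group does not recover the activity of compound 1, which stays the most active of the four. The step between compound 2 and compound 4 cannot be read.

As far as these compounds go, it remains open how methoxy, propoxy or a dimethylamino group on this carbonyl carbon would compare with ethoxy. From the compounds shown here alone, how far compound 4 lies past the limit also stays unknown.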